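Oxazole to Pyrazole on the Amide of Compound 3

The compounds below may be only part of what the source reports. "The series", "measured", "known", "first", "only" and "open" are said of these compounds alone.

Of the compounds shown here, three have been measured in a functional assay on CHO-K1 cells for agonist activity at somatostatin receptor type 2 (Homo sapiens), read by cAMP accumulation, with a stated time of 30 min; a higher number here means that more compound is needed for the effect, a lower number that less compound is needed. Compound 1 `Cc1cc(C)cc(-c2cncc(-c3nc4cc(C(F)(F)F)ccc4[nH]3)c2N2CCC(N)CC2)c1` gives 0.014 nM, and compound 2 `NC1CCN(c2c(-c3cc(F)cc(Cl)c3)cncc2-c2nc3cc(F)ccc3[nH]2)CC1` gives 0.081 nM. Compound 3 `Cc1nc(C(=O)Nc2cncc(-c3cc(Cl)cc(Cl)c3)c2N2CCC(N)CC2)c(C)o1`, the amide-linked member of the set, gives 0.47 nM, the highest number of the three; its nearest neighbour is compound 2, and its furthest is compound 1, with both gaps lying beyond the usual scatter. Compound 4 `Cc1nn(C)cc1C(=O)Nc1cncc(-c2cc(Cl)cc(Cl)c2)c1N1CCC(N)CC1` keeps the core and the amide of compound 3 and changes only the ring on the carbonyl carbon: 1,3-dimethyl-1H-pyrazol-4-yl in place of 2,5-dimethyl-1,3-oxazol-4-yl on a carbonyl carbon. Going by the values given here, the two rings are of the same size and carry the same count of methyl groups and hydrogen-bond acceptors, and no measured pair in this set shows what such an exchange does. The step from compound 3 to compound 4 is therefore expected to be small, in either direction, and likely to stay within the scatter, as a 1.1-fold higher number from compound 3 to compound 4 (0.03 log units; within the scatter) expresses. Compound 4 is estimated to give 0.5 nM in this assay, with a range from 0.15 nM to 1.6 nM.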

Compound 4, half-maximal effective concentration: 0.12 nM
Estimate against measurement, compound 4: 4.2-fold (0.62 log units) above; the whole stated range lies above it.
By their numbers in this assay, from the lowest: compound 1; then compounds 2 and 4 (each within the scatter of the next); then compound 3.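

In this assay, going by these compounds alone, the exchange of 2,5-dimethyl-1,3-oxazol-4-yl for 1,3-dimethyl-1H-pyrazol-4-yl on a carbonyl carbon gives a 3.9-fold lower number from compound 3 to compound 4 (0.59 log units; beyond the scatter) as the first step in this set that can be read at one place. It shows that this position responds to the identity of the ring, even though both rings are five-membered and aromatic, with the same counts of heavy atoms, hetero atoms and hydrogen-bond acceptors. Nothing at hand gives a measured reason for the difference between the two rings.

The compounds shown leave open whether the two methyl groups on the pyrazole contribute to this step, as a 1H-pyrazol-4-yl without them or with an ethyl group on the ring nitrogen would test. They also leave open how an amino group on the same ring would read.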